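The source may report more compounds than this note shows. Statements on the series, on what has been measured and on what is new or still open speak of the compounds shown alone.

Of the compounds shown here, three sharing one core have been measured in a functional assay on SMMC-7721 cells (Homo sapiens) for antiproliferative activity, read by MTT assay, with a stated time of 72 h; a higher number here means a weaker inhibitor, a lower number a stronger inhibitor. Compound 1 `CCC(=O)N(C)c1ccc2[nH]c(-c3n[nH]c4ccccc34)cc2n1` gives 33500 nM in this assay. Compound 2 `CN(C(=O)c1ccc(Br)cc1)c1ccc2[nH]c(-c3n[nH]c4ccccc34)cc2n1` gives 3460 nM, and compound 3 `Cc1ccc(S(=O)(=O)N(C)c2ccc3[nH]c(-c4n[nH]c5ccccc45)cc3n2)cc1` gives 16300 nM. Compound 3 thus stands second highest of the three numbers, nearest to compound 1 and furthest from compound 2; the measured steps are a 2.1-fold lower number from compound 1 to compound 3 (0.31 log units; beyond the scatter) and a 4.7-fold higher number from compound 2 to compound 3 (0.67 log units; beyond the scatter), while a 9.7-fold lower number from compound 1 to compound 2 (0.99 log units; beyond the scatter) is the largest of the set. Compound 4 `CN(c1ccc2[nH]c(-c3n[nH]c4ccccc34)cc2n1)S(=O)(=O)c1cccc([N+](=O)[O-])c1` has not yet been measured. It differs from compound 3 in one place: 3-nitrophenyl in place of 4-methylphenyl on a sulfonyl sulfur. Among the compounds with values here, none of the measured steps bears directly on this change; all three exchange the whole substituent on a nitrogen on an aromatic ring, and none alters the group on the sulfonyl sulfur, so they set only the scale of change seen so far, which was modest throughout. An exchange of one ring for another on the sulfonyl sulfur is therefore expected to move the number little, with no direction that can be called with confidence. Compound 4 is expected to give 12000 nM in this assay, between 4000 nM and 40000 nM. That estimate means an expected step of a 1.4-fold lower number from compound 3 to compound 4 (0.13 log units; within the scatter).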

Compound 4, half-maximal inhibitory concentration: 5070 nM
Compound 4: middle estimate off by 2.4-fold (0.37 log units), on the high side, and the stated range covers the measured number.
By their numbers in this assay, from the lowest: compounds 2 and 4 (each within the scatter of the next); then compound 3; then compound 1.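

The exchange of 4-methylphenyl for 3-nitrophenyl on a sulfonyl sulfur gives a 3.2-fold lower number from compound 3 to compound 4 (0.51 log units; beyond the scatter) in this assay and is the first step shown at this place, so the ring group on the sulfonyl sulfur can move the number even with the sulfonamide nitrogen and the shared core left unchanged. The step alters both the ring's substituent and where that substituent sits, so this single pair cannot separate the two changes. No measurement shown here explains the step.

On these data alone, it remains open whether 3-methylphenyl or 4-nitrophenyl on the sulfonyl sulfur would track the substituent or its place on the ring. As far as these compounds go, how an amine or a carboxylic acid on that ring would compare also remains open.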